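Methoxy in Place of Chloro: Expected Shift for Compound 4

This account rests on a few compounds, and the source may have more. Where it says the series, first, only, none or still open, it means among the compounds named here.

Compound 1 `Cc1nc(-c2ccc(Cl)cc2)sc1C(=O)CSc1nc(-c2ccc(Cl)c(Cl)c2)c(C#N)c(=O)[nH]1`: 83900 nM
Compound 2 `COc1ccc(-c2nc(SCC(=O)c3sc(-c4ccccc4)nc3C)nc(N)c2C#N)cc1`: 14000 nM
Compound 3 `COc1ccc(-c2nc(C)c(C(=O)CSc3nc(N)c(C#N)c(-c4ccc(OC)cc4)n3)s2)cc1`: 1560 nM

In a functional assay on U-87MG ATCC cells for antiproliferative activity against U-87 MG (Homo sapiens), read by MTT assay, with a stated time of 48 h (on this read-out lower numbers stand for stronger inhibition and higher numbers for weaker inhibition), compound 1 gives 83900 nM, the highest number of the three measured compounds; compound 2 and compound 3 both give lower numbers. Compound 4 `COc1ccc(-c2nc(C)c(C(=O)CSc3nc(-c4ccc(Cl)c(Cl)c4)c(C#N)c(=O)[nH]3)s2)cc1` differs from compound 1 by methoxy in place of chloro on an aromatic carbon, read one bond further out as 4-chlorophenyl to 4-methoxyphenyl. Going by the values given here, the only measured step that bears on this is a 9.0-fold lower number from compound 2 to compound 3 (0.95 log units; beyond the scatter), where methoxy entered in place of hydrogen rather than chloro, so it is an imperfect guide. A step of similar direction but smaller size is expected, a 5.6-fold lower number from compound 1 to compound 4 (0.75 log units; beyond the scatter), with compound 4 estimated at 15000 nM, within a range from 4000 nM to 55000 nM.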

Compound 4, half-maximal inhibitory concentration: 68500 nM
For compound 4 the middle estimate is 4.6-fold (0.66 log units) below the measured one; measured number outside the range, above it.
By their numbers in this assay, from the lowest: compound 3; then compound 2; then compounds 4 and 1 (each within the scatter of the next).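

Replacing 4-chlorophenyl with 4-methoxyphenyl gives a 1.2-fold lower number from compound 1 to compound 4 (0.09 log units; within the scatter) in this assay, so on this core chloro and methoxy at this position cannot be told apart. The earlier step, a 9.0-fold lower number from compound 2 to compound 3 (0.95 log units; beyond the scatter), had methoxy replacing hydrogen on a different core and lay beyond the scatter, and that size does not carry over to methoxy replacing chloro. Nothing available explains this difference between the two steps.

From the compounds shown here alone, whether hydrogen at this position on the core of compound 1 would read differently remains open. So does how a fluoro or an amine group would read there.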